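From methylsulfanyl to methylsulfonyl on a shared core

The source may hold more compounds than are shown below. What is called first, only, known or untested is meant among the compounds shown, and "the series" means these compounds.

Measured in a functional assay on HEp-2 cells (Homo sapiens) for cytotoxicity; on this read-out higher numbers stand for weaker inhibition and lower numbers for stronger inhibition:
Compound 1 `Nc1nc(O)c2nnn(C3O[C@H](CO)[C@@H](O)[C@H]3O)c2n1`: 2000 nM
Compound 2 `CSc1nc(N)c2nnn(C3O[C@H](CO)[C@@H](O)[C@H]3O)c2n1`: > 130000 nM

For compound 2, the reading is only a limit (> 130000 nM). Compound 3 `CS(=O)(=O)c1nc(N)c2nnn(C3O[C@H](CO)[C@@H](O)[C@H]3O)c2n1`, still unmeasured in this assay, has methylsulfonyl in place of methylsulfanyl on an aromatic carbon. Within the data shown here, no measured step gives the size of this change, so only a small shift toward stronger inhibition is expected, possibly none beyond the scatter. The expected step (an at least 1.3-fold lower number from compound 2 to compound 3 (0.11 log units; that floor lies within the scatter)) remains tentative. Compound 3 is estimated at 100000 nM, with an expected range of 25000 nM to 300000 nM.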

Compound 3, half-maximal inhibitory concentration: 14000 nM
Beside the measured number, compound 3's estimate is 7.1-fold (0.85 log units) above it; measured number below the stated range.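

In this assay, methylsulfonyl in place of methylsulfanyl on the aromatic carbon between two ring nitrogen atoms gives an at least 9.2-fold lower number from compound 2 to compound 3 (0.96 log units; beyond the scatter). Among these compounds, this is the first one-place comparison, and it shows that the read-out responds to a change at this position, beyond the scatter. The true size of the step stays unknown, as compound 2 has only a limit: the limit of > 130000 nM in this assay, at which 1 of the 3 values shown sits.

As far as these compounds go, how an amine or a longer alkylsulfonyl chain on this carbon would read in this assay remains open.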